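Chlorine Added to Two Salicylanilides: Expectation for Compound 4

The source may report more compounds than this note shows. Statements on the series, on what has been measured and on what is new or still open speak of the compounds shown alone.

Compound 1 `O=C(Nc1ccc(OC(F)(F)F)cc1)c1cc(F)ccc1O` gives 810 nM in a functional assay on Jurkat cells (Homo sapiens) for cytotoxicity, read by luminescence and CellTiter-Glo, with a stated time of 3 days; a lower number here means a stronger inhibitor, a higher number a weaker inhibitor.
Compound 2 `O=C(Nc1ccc(OC(F)(F)F)c(Cl)c1)c1cc(F)ccc1O` gives 700 nM in this assay.
Compound 3 `O=C(Nc1cccc(C(F)(F)F)c1)c1cc(F)ccc1O` gives 840 nM in this assay.

The three measured values sit close together, and none is set apart from the others beyond the usual scatter. Compound 1 and compound 2 differ by one change, (chloro in place of hydrogen on an aromatic carbon), and the step is a 1.2-fold lower number from compound 1 to compound 2 (0.06 log units; within the scatter). How the core of compound 3 differs from the core of compound 1 is not broken down here.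

Compound 4 `O=C(Nc1ccc(Cl)c(C(F)(F)F)c1)c1cc(F)ccc1O` differs from compound 3 by chloro in place of hydrogen on an aromatic carbon. This is the same kind of change as that from compound 1 to compound 2, but not the same: here the chlorine enters ortho to a trifluoromethyl group and para to a large group, whereas in compound 2 it sits ortho to a trifluoromethoxy group and meta to a large group.

In this assay the step from compound 3 to compound 4 is expected to be small, a 1.1-fold lower number from compound 3 to compound 4 (0.05 log units; within the scatter), because the earlier step of a 1.2-fold lower number from compound 1 to compound 2 (0.06 log units; within the scatter) stayed within the scatter. Compound 4 is therefore estimated at 750 nM, with a likely span from 400 nM to 1400 nM.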

Compound 4, half-maximal inhibitory concentration: 530 nM
For compound 4 the middle estimate is 1.4-fold (0.15 log units) above the measured one; measured number inside the range.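

In this assay putting chloro in place of hydrogen on an aromatic carbon gave a 1.6-fold lower number from compound 3 to compound 4 (0.20 log units; within the scatter) on this second core, so once more the change stayed within the usual scatter of repeated measurements. Set side by side, the two steps do not differ by more than such steps can by chance: the same change on two cores in this assay, a 1.2-fold lower number (0.06 log units; within the scatter) from compound 1 to compound 2 and a 1.6-fold lower number (0.20 log units; within the scatter) from compound 3 to compound 4, 1.4-fold (0.14 log units) apart, within the scatter of two such steps. This shows that, on these two cores, the change carried across without a step that stands out, even though the chlorine sits in a different setting on each; it does not show that chloro makes these compounds stronger inhibitors, and two cores cannot predict what happens on a third.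

The compounds shown leave open whether another group in the same place, such as a methyl group, a methoxy group or an amine, would give a step beyond the scatter. They also leave open how chloro would behave on a core carrying neither trifluoromethyl nor trifluoromethoxy.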